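Methyl scan on the carbamoyl-bearing ring of the thiazole series

The source may report more compounds than this note shows. Statements on the series, on what has been measured and on what is new or still open speak of the compounds shown alone.

Compound 1 `Cc1nc(Cc2cccc(C(F)(F)F)c2)sc1-c1ccc(C(N)=O)cc1` is the unsubstituted parent of this small set. For the measured compounds named here, in a functional assay on cells for agonist activity at G-protein coupled receptor 52 (Homo sapiens), read by AlphaScreen and cAMP accumulation, with a stated time of 30 min (a higher number here means that more compound is needed for the effect, a lower number that less compound is needed), compound 1 gives 220 nM, the highest of the two numbers measured so far; its nearest neighbour is compound 2 `Cc1cc(-c2sc(Cc3cccc(C(F)(F)F)c3)nc2C)ccc1C(N)=O`, which in this assay gives 73 nM, a step of a 3.0-fold lower number from compound 1 to compound 2 (0.48 log units; beyond the scatter). Going by the values given here, that step is the only one measured, and it is the one change of the same kind: a methyl entering an aromatic carbon of the carbamoyl-bearing ring, though in compound 2 the methyl sits on a different aromatic carbon of that ring.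

Compound 3 `Cc1cc(C(N)=O)ccc1-c1sc(Cc2cccc(C(F)(F)F)c2)nc1C` differs from compound 1 by methyl in place of hydrogen on an aromatic carbon. Among the compounds with values here, only the step from compound 1 to compound 2 bears on it, and it was modest; whether a methyl at this other aromatic carbon behaves the same way is not known from the data. A step of similar direction but smaller size, or none beyond the scatter, is the expectation in this assay, giving a 1.5-fold lower number from compound 1 to compound 3 (0.17 log units; within the scatter). Compound 3 is therefore estimated at 150 nM, with a range from 50 nM to 450 nM.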

Compound 3, half-maximal effective concentration: 1400 nM
For compound 3 the middle estimate is 9.3-fold (0.97 log units) below the measured one; the whole stated range lies below it.
By their numbers in this assay, from the lowest: compound 2; then compound 1; then compound 3.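

Methyl in place of hydrogen on this ring has no single direction in this assay: on the aromatic carbon ortho to a large group and meta to a carbamoyl group the change gives a 6.4-fold higher number from compound 1 to compound 3 (0.80 log units; beyond the scatter), whereas on the other aromatic carbon it gives a 3.0-fold lower number from compound 1 to compound 2 (0.48 log units; beyond the scatter). Both steps are printed as beyond the scatter, so in this pair of changes the outcome depends on which aromatic carbon takes the methyl, and the present position is one where a single added carbon raises the number rather than lowers it, which the earlier step alone could not show. Nothing available here bears on why the two positions part in this way.

Still open, on these data alone, is whether the rise at this position is particular to methyl or would also follow from a fluorine atom, a chlorine atom, a methoxy group or an ethyl group on the same carbon. Also open, as far as these compounds go, is how a methyl on this carbon would read in combination with a methyl on the other aromatic carbon, and whether the same contrast holds on other versions of the core.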